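The source may hold more compounds than are shown below. What is called first, only, known or untested is meant among the compounds shown, and "the series" means these compounds.

Measured compounds in an assay on isolated protein for displacement of a labelled ligand from secreted frizzled-related protein 1 (Homo sapiens), read by fluorescence polarization, with a stated time of 30 min; a higher number here means a weaker inhibitor, a lower number a stronger inhibitor:
- compound 1 `O=C(c1ccccc1)N1CCC(NS(=O)(=O)c2cc(S(=O)(=O)c3ccccc3)ccc2C(F)(F)F)CC1`: 70 nM
- compound 2 `O=C(c1ccc(C(F)(F)F)cc1)N1CCC(NS(=O)(=O)c2cc(S(=O)(=O)c3ccccc3)ccc2C(F)(F)F)CC1`: 400 nM
- compound 3 `CN(C)c1ccc(C(=O)N2CCC(NS(=O)(=O)c3cc(S(=O)(=O)c4ccccc4)ccc3C(F)(F)F)CC2)cn1`: 40 nM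

Compound 3 gives the lowest number of the three in this assay. Its nearest neighbour is compound 1, with a 1.8-fold lower number from compound 1 to compound 3 (0.24 log units; within the scatter), which lies within the scatter, so no order between compound 1 and compound 3 is claimed. Compound 2 stands furthest away, with a 10-fold lower number from compound 2 to compound 3 (1.00 log units; beyond the scatter).

Compound 4 `O=C(O)CCCC(=O)N1CCC(NS(=O)(=O)c2cc(S(=O)(=O)c3ccccc3)ccc2C(F)(F)F)CC1` differs from compound 3 at the amide substituent: 3-carboxypropyl in place of 6-(dimethylamino)pyridin-3-yl on a carbonyl carbon. All three measured steps vary this same position and therefore bear on the change, but each of them exchanges one aromatic group for another. They range from a 5.7-fold higher number from compound 1 to compound 2 (0.76 log units; beyond the scatter), which is beyond the scatter, to a 10-fold lower number from compound 2 to compound 3 (1.00 log units; beyond the scatter), with a 1.8-fold lower number from compound 1 to compound 3 (0.24 log units; within the scatter) within it. None of them replaces a ring with an open chain, so the change to compound 4 lies outside what has been measured. Given that aromatic variation alone already moved this assay beyond the scatter, a step in the direction of a weaker inhibitor is expected for compound 4, with considerable uncertainty. Compound 4 is estimated at 300 nM in this assay, within a range of 60 nM to 1500 nM. The expected step is a 7.5-fold higher number from compound 3 to compound 4 (0.88 log units; beyond the scatter).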

Compound 4, half-maximal inhibitory concentration: 500 nM
Beside the measured number, compound 4's estimate is 1.7-fold (0.22 log units) below it; measured number inside the range.
By their numbers in this assay, from the lowest: compounds 3 and 1 (each within the scatter of the next); then compounds 2 and 4 (each within the scatter of the next).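

In this assay, this position on the carbonyl carbon now carries an open chain as well as aromatic rings, and replacing the ring of compound 3 with 3-carboxypropyl gives a large step, a 13-fold higher number from compound 3 to compound 4 (1.10 log units; beyond the scatter). The replacement of plain phenyl also lies beyond the scatter, a 7.1-fold higher number from compound 1 to compound 4 (0.85 log units; beyond the scatter), whereas a 1.3-fold higher number from compound 2 to compound 4 (0.10 log units; within the scatter) does not separate 3-carboxypropyl from 4-(trifluoromethyl)phenyl. Having a ring at this position is therefore not enough on its own to set the reading, since compound 2 carries one and stays within the scatter of the ringless compound 4. Nothing on hand explains these steps.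

Still open, going by these compounds, is whether the step follows the loss of the ring or the presence of the carboxylic acid. A plain alkyl chain, an amine-ended chain or a longer chain ending in a carboxylic acid would help separate these.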